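The compounds below may be only part of what the source reports. "The series", "measured", "known", "first", "only" and "open" are said of these compounds alone.

Measured compounds in an ADME assay on MT4 cells (Homo sapiens) for cytotoxicity, read by MTT assay, with a stated time of 5 days; a higher number here means that more compound is tolerated, a lower number that less compound is tolerated:
Compound 1 `CCCCCNc1cc(Oc2c(OC)cc3cc(C#N)ccc3c2OC)nc(Nc2ccc(C#N)cc2)n1` — compound 1 gives > 125000 nM, a limit of the assay rather than a number.
Compound 2 `CCCC(C)Nc1cc(Oc2c(OC)cc3cc(C#N)ccc3c2OC)nc(Nc2ccc(C#N)cc2)n1` — compound 2 gives > 125000 nM, again a limit.
Compound 3 `COc1cc2cc(C#N)ccc2c(OC)c1Oc1cc(NC2CCCC2)nc(Nc2ccc(C#N)cc2)n1` — compound 3 gives > 125000 nM, again a limit.

Where compound 1 stands in this assay: only a limit is known for it, and the two further values shown are limits as well, so every measured member of the series sits at the limit of > 125000 nM in this assay, at which 3 of the 3 values shown sit. Within the data shown here, no compound can be ranked against another on these numbers.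

The step considered runs from compound 1 to compound 4 `COc1cc2cc(C#N)ccc2c(OC)c1Oc1cc(NCCC2=CCCCC2)nc(Nc2ccc(C#N)cc2)n1`. The change is cyclohex-1-en-1-yl in place of propyl on a saturated chain carbon, two bonds along the chain from a nitrogen on an aromatic ring.

The measured steps that bear on it are those changing the group on the nitrogen on the aromatic ring: a step that the two limits leave unreadable from compound 1 to compound 2, a step that the two limits leave unreadable from compound 1 to compound 3 and a step that the two limits leave unreadable from compound 2 to compound 3. None of them has a readable size, since each pair sits at the same limit. Among the measured compounds shown here, they give no direction and no magnitude for the step in this assay; what they do show is that three variations of the group on that nitrogen all stayed at the limit.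

Compound 4 is therefore expected to behave the same way, with a number no higher from compound 1 to compound 4 (the limit leaves the size open) expected to be no readable step. The estimate for compound 4 in this assay is 125000 nM, within 50000 nM to 250000 nM, most probably again reported as a limit.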

Compound 4, half-maximal cytotoxic concentration: > 125000 nM
Compound 4 ended at the assay's limit (the forecaster's own chance of this, stated with the estimate: 80%); the middle value sits exactly at the limit.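

In this assay compound 4 gives > 125000 nM, a limit of the assay and not a number. No step between compound 4 and compound 1, compound 2 or compound 3 can be read, because all four compounds share one limit: the limit of > 125000 nM in this assay, at which 4 of the 4 values shown sit.

The compounds shown leave open how much of any of them is actually tolerated, and whether any group on that nitrogen would give a readable value.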